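The source may hold more compounds than are shown below. What is called first, only, known or untested is meant among the compounds shown, and "the series" means these compounds.

Measured so far in an ADME assay on Huh-7 cells (Homo sapiens) for cytotoxicity; a higher number here means that more compound is tolerated, a lower number that less compound is tolerated:
- compound 1, `Cc1ccccc1-c1nn(-c2cccc(Cl)c2)cc1CNCCN1CCN(C)CC1`: 16000 nM
- compound 2, `CN1CCN(CCCNCc2cn(-c3ccc([N+](=O)[O-])cc3)nc2-c2ccc(Cl)cc2)CC1`: 3700 nM

Compound 1 gives the highest of the two numbers in this assay; its nearest neighbour is compound 2, whose number is lower by more than the scatter. Compounds 1 and 2 differ in several places, so no single step between them can be read; only the two values themselves are shown.

Compound 3 is `CCOC(=O)Cn1cc(CNCCN2CCN(C)CC2)c(-c2ccccc2C)n1` and awaits measurement in this assay. Against compound 1 the change is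
(ethoxycarbonyl)methyl in place of 3-chlorophenyl on an aromatic nitrogen
Within the data shown here, no measured pair covers this change, so the size of the step rests on no precedent. The expectation is for a step of modest size, a 1.6-fold higher number from compound 1 to compound 3 (0.19 log units; within the scatter), toward a higher number in this assay, with a reading within the scatter of compound 1 well possible. For compound 3 the estimate in this assay is 25000 nM, with a range from 8000 nM to 80000 nM.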

Compound 3, half-maximal cytotoxic concentration: > 20000 nM
Compound 3: no number, only a limit; the forecaster's own chance of this, stated with the estimate: 30%; the middle value does not contradict the limit.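

In this assay compound 3 gives > 20000 nM, which is a limit of the assay and not a number. Replacing 3-chlorophenyl with (ethoxycarbonyl)methyl on the aromatic nitrogen gives an at least 1.2-fold higher number from compound 1 to compound 3 (0.09 log units; that floor lies within the scatter), so this position, the first of the series seen with a change in one place, takes a group with no ring and no lower number appears in this assay. The true size of this step cannot be read, and the reading ends at the limit of the assay: the limit of > 20000 nM in this assay, at which 1 of the 3 values shown sits.

With this single change at the position, the ring's removal and the ester's arrival cannot be told apart. Going by these compounds, whether the same reading holds for a carboxylic acid in place of the ethyl ester, or for a longer chain or a simple methyl on the aromatic nitrogen, stays open.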